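This account rests on a few compounds, and the source may have more. Where it says the series, first, only, none or still open, it means among the compounds named here.

Compound 1, with the structure `COc1cccc(/C=C/C(=O)C(=Cc2ccc(O)c(F)c2)C(=O)/C=C/c2cccc(OC)c2OC)c1OC`, is one of three measured members of a small series of bis-styryl ketones tested in a functional assay on SW480 cells (Homo sapiens) for antiproliferative activity, read by sulforhodamine B assay, with a stated time of 48 h (a higher number here means a weaker inhibitor, a lower number a stronger inhibitor), where compound 1 gives 330 nM. Compound 2, `COc1cc(C=C(C(=O)/C=C/c2cccc(OC)c2OC)C(=O)/C=C/c2cccc(OC)c2OC)cc(OC)c1O`, carries 4-hydroxy-3,5-dimethoxyphenyl in place of 3-fluoro-4-hydroxyphenyl on a double-bonded chain carbon bound to a double-bonded chain carbon, and in this assay compound 2 gives 420 nM, a step of a 1.3-fold higher number from compound 1 to compound 2 (0.10 log units; within the scatter). Compound 3, `COc1ccc(OC)c(/C=C/C(=O)C(=Cc2ccc(O)c(F)c2)C(=O)/C=C/c2cc(OC)ccc2OC)c1`, shares its atoms with compound 1 but joins them differently; how the two cores differ is not broken down here. In this assay compound 3 gives 510 nM, which sits close to the numbers of compound 1 and compound 2 and cannot be separated from them.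

Compound 4, `COc1ccc(OC)c(/C=C/C(=O)C(=Cc2cc(OC)c(O)c(OC)c2)C(=O)/C=C/c2cc(OC)ccc2OC)c1`, has not yet been measured. It relates to compound 3 exactly as compound 2 relates to compound 1: it carries 4-hydroxy-3,5-dimethoxyphenyl in place of 3-fluoro-4-hydroxyphenyl on a double-bonded chain carbon bound to a double-bonded chain carbon, the same change at the same place. The step from compound 1 to compound 2 was small, so the expected step from compound 3 to compound 4 is estimated at a 1.3-fold higher number from compound 3 to compound 4 (0.11 log units; within the scatter), resting on the measured 1.3-fold higher number from compound 1 to compound 2 (0.10 log units; within the scatter). On that basis compound 4 is expected to give about 650 nM in this assay, with a plausible range from 350 nM to 1200 nM.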

Compound 4, half-maximal inhibitory concentration: 500 nM
Compound 4: the middle estimate sits 1.3-fold (0.11 log units) above what was measured; the measured number falls inside the stated range.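

In this assay, 4-hydroxy-3,5-dimethoxyphenyl in place of 3-fluoro-4-hydroxyphenyl gives a 1.0-fold lower number from compound 3 to compound 4 (0.01 log units; within the scatter), so on the core of compound 3, as on the core of compound 1, the step stays within the scatter. Set side by side, the two steps cannot be told apart: the same change on two cores in this assay, a 1.3-fold higher number (0.10 log units; within the scatter) from compound 1 to compound 2 and a 1.0-fold lower number (0.01 log units; within the scatter) from compound 3 to compound 4, 1.3-fold (0.11 log units) apart, within the scatter of two such steps. Among these compounds, this shows that the change carries over between these two cores without a step that can be separated from the scatter, but it rests on only two pairs and does not show that the two groups would be interchangeable on any other core.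

The compounds shown leave open whether an amine or a carboxylic acid on the phenyl ring at this double-bonded chain carbon would stay as close to these numbers. They also leave open what a longer chain in place of the methoxy groups of 4-hydroxy-3,5-dimethoxyphenyl would give.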